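The compounds below may be only part of what the source reports. "The series", "measured", "known", "first", "only" and "open" are said of these compounds alone.

Compound 3 `Fc1ccccc1Cn1nnc2c(NC3CC3)nc(-c3ccccc3)nc21` is one of the three measured compounds in an assay on isolated protein for binding affinity to adenosine receptor A1 (Bos taurus) (on this read-out higher numbers stand for weaker inhibition and lower numbers for stronger inhibition), where compound 3 gives 15000000 nM. Compound 1 `CCCCCCNc1nc(-c2ccccc2)nc2c1nnn2Cc1ccccc1` gives 13200000 nM, a value that sits within the scatter of compound 3. Within the data shown here, compound 2 `Fc1ccccc1Cn1nnc2c(NC3CCCCC3)nc(-c3ccccc3)nc21` gives 1150000 nM, and the step of a 13-fold higher number from compound 2 to compound 3 (1.12 log units; beyond the scatter) is the only change on the amine nitrogen measured so far. Compound 4 `CCCCCCNc1nc(-c2ccccc2)nc2c1nnn2Cc1ccccc1F` takes the step (hexyl in place of cyclopropyl on a nitrogen on an aromatic ring). Among the measured compounds shown here, no measured step has this exact change; the comparison of compound 1 with compound 3 spans the same hexyl-for-cyclopropyl exchange together with a fluorine on the benzyl ring, and those two values show no difference beyond the scatter. The step from compound 2 to compound 3 shows that a larger ring carried a much lower number, but a straight chain is not a ring, and compound 1 suggests little change. The expectation for compound 4 in this assay is therefore a step of a 1.5-fold lower number from compound 3 to compound 4 (0.18 log units; within the scatter), close to compound 1. The estimate for compound 4 is 10000000 nM, within 3000000 nM to 30000000 nM.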

Compound 4, inhibition constant: 25000000 nM
Estimate against measurement, compound 4: 2.5-fold (0.40 log units) below, and the stated range covers the measured number.
By their numbers in this assay, from the lowest: compound 2; then compounds 1, 3 and 4 (each within the scatter of the next).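

In this assay the direct exchange on the amine nitrogen (a 1.7-fold higher number from compound 3 to compound 4 (0.22 log units; within the scatter)) stays within the scatter, so with the fluorine on the benzyl ring held in place, hexyl and cyclopropyl are not separated. Cyclohexyl stands apart from hexyl as well (a 22-fold higher number from compound 2 to compound 4 (1.34 log units; beyond the scatter)), so among these three groups only compound 2 differs beyond the scatter, and carrying a ring does not alone set it apart, as the cyclopropyl of compound 3 is also a ring. The fluorine, now read on its own (a 1.9-fold higher number from compound 1 to compound 4 (0.28 log units; within the scatter)), also stays within the scatter with the hexyl group in place.

No available evidence explains why the cyclohexyl compound stands apart. Open, going by these compounds, is whether cyclopentyl, cycloheptyl or a longer chain such as octyl on the amine nitrogen would give a number near that of compound 2 or near those of compound 3 and compound 4.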